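Swapping a Ring Substituent in a T-Cell Inhibitor Series

The source may hold more compounds than are shown below. What is called first, only, known or untested is meant among the compounds shown, and "the series" means these compounds.

Of the compounds shown here, three sharing one core have been tested in a functional assay on cells (T-cell, Homo sapiens) for inhibition; a higher number here means a weaker inhibitor, a lower number a stronger inhibitor. Compound 1 `CC(C)Oc1nc(N)nc2ncc(-c3ccc(F)c(F)c3)nc12` gives 10000 nM in this assay, and compound 2 `CCOc1nc(N)nc2ncc(-c3ccc(C(F)(F)F)cc3)nc12` gives 10000 nM. Compound 3 `COc1ccc(-c2cnc3nc(N)nc(N4CCN(c5ccc(C)cc5)CC4)c3n2)cc1OC` gives 300 nM, the lowest of the three numbers and beyond the usual scatter from both others. Compound 4 `COc1ccc(-c2cnc3nc(N)nc(N4CCN(C(=O)Nc5ccc(C#N)cc5)CC4)c3n2)cc1OC` has not yet been measured. It differs from compound 3 in one place: (4-cyanophenyl)carbamoyl in place of 4-methylphenyl on an amine nitrogen in a ring. Going by the values given here, no measured pair shows what such a change does here, so its direction remains open. The expected step, a 2.0-fold higher number from compound 3 to compound 4 (0.30 log units; within the scatter), is modest and leans slightly toward weaker inhibition. Compound 4 is therefore estimated at 600 nM, with a likely range from 120 nM to 3000 nM.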

Compound 4, half-maximal inhibitory concentration: 74 nM
Compound 4: the middle estimate sits 8.1-fold (0.91 log units) above what was measured, outside the stated range (below it).
By their numbers in this assay, from the lowest: compound 4; then compound 3; then compounds 1 and 2 (each within the scatter of the next).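

In this assay, putting (4-cyanophenyl)carbamoyl in place of 4-methylphenyl on the amine nitrogen in the ring gives a 4.1-fold lower number from compound 3 to compound 4 (0.61 log units; beyond the scatter). This position therefore accepts a larger group that carries a carbonyl and an amide hydrogen, and inhibition grows stronger with it. Nothing measured here explains this gain.

From the compounds shown here alone, the change alters the link to the aromatic ring and the group on that ring together, so the source of the step stays open. A (4-methylphenyl)carbamoyl group, or a plain phenylcarbamoyl, would help separate these two parts.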